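This account rests on a few compounds, and the source may have more. Where it says the series, first, only, none or still open, it means among the compounds named here.

In a functional assay on PC-3 cells (Homo sapiens) for inhibition, read by MTT assay, with a stated time of 48 h (on this read-out lower numbers stand for stronger inhibition and higher numbers for weaker inhibition), compound 1 `COc1cc(C2=NOC(c3c[nH]c4ccccc34)C2)cc(OC)c1OC` gives 15500 nM. Compound 2 `COc1ccc(C2=NOC(c3c[nH]c4ccccc34)C2)cc1OC` in this assay gives 70100 nM. The pair differs by methoxy in place of hydrogen on an aromatic carbon, and the step is a 4.5-fold lower number from compound 2 to compound 1 (0.66 log units; beyond the scatter). Compound 3 `c1ccc2c(C3CC(c4ccncc4)=NO3)c[nH]c2c1` in this assay returns only a limit of the assay, > 100000 nM, and so stands at the limit of > 100000 nM in this assay, at which 1 of the 3 values shown sits. The difference between the core of compound 3 and the core of compound 2 is not broken down here. Compound 4 `COc1ccc2[nH]cc(C3CC(c4ccncc4)=NO3)c2c1` is not yet measured; it differs from compound 3 by methoxy in place of hydrogen on an aromatic carbon, the same kind of change as between compound 2 and compound 1, though here on a ring that is part of a fused or bridged system of two rings, meta to a fused ring and para to a fused ring, rather than ortho to a methoxy group, meta to a large group and meta to a methoxy group. Compound 4 is expected to move by an at least 1.6-fold lower number from compound 3 to compound 4 (0.22 log units; that floor lies within the scatter), an expectation resting on a 4.5-fold lower number from compound 2 to compound 1 (0.66 log units; beyond the scatter) but held loosely because compound 3 sits at the limit of > 100000 nM in this assay, at which 1 of the 3 values shown sits. Compound 4 is therefore estimated at 60000 nM in this assay, within a range from 15000 nM to 150000 nM.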

Compound 4, half-maximal inhibitory concentration: > 100000 nM
Compound 4 ended at the assay's limit; the forecaster's own chance of this, stated with the estimate: 40%; middle value at least 1.6-fold (0.22 log units) away from the limit.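

Compound 3 and compound 4 both sit at the assay's limit, so no step can be read between them: the limit of > 100000 nM in this assay, at which 2 of the 4 values shown sit.

From the compounds shown here alone, whether methoxy in place of hydrogen changes the number on the core of compound 3 in this assay stays open.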